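Moving the methoxy group on the anilino ring

A few compounds are considered here, and "the series" means these few. Any claim that something is new, unique, unknown or untested is made for them only; others in the source may bear on it.

Compound 1 `Cc1ccc(NC2=CC(=O)c3nc4n(c3C2=O)[C@H]2OC[C@@H](O)[C@H]2OC4)cc1` gives 1420 nM in a functional assay on MGC-803 cells (Homo sapiens) for inhibition, read by sulforhodamine B assay; a higher number here means a weaker inhibitor, a lower number a stronger inhibitor.
Compound 2 `CCCc1ccc(NC2=CC(=O)c3nc4n(c3C2=O)[C@H]2OC[C@@H](O)[C@H]2OC4)cc1` gives 1560 nM.
Compound 3 `COc1ccc(NC2=CC(=O)c3nc4n(c3C2=O)[C@H]2OC[C@@H](O)[C@H]2OC4)cc1` gives 1680 nM.

All three compounds share one core and differ only in the group carried by the ring on the amine nitrogen. The steps between them are small: a 1.1-fold higher number from compound 1 to compound 2 (0.04 log units; within the scatter), a 1.2-fold higher number from compound 1 to compound 3 (0.07 log units; within the scatter) and a 1.1-fold higher number from compound 2 to compound 3 (0.03 log units; within the scatter). Compound 3 therefore sits alongside compound 1 and compound 2, with none of the three separated from another by more than the scatter.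

Compound 4 `COc1ccccc1NC1=CC(=O)c2nc3n(c2C1=O)[C@H]1OC[C@@H](O)[C@H]1OC3` is not yet measured. It differs from compound 3 only in where the methoxy group sits: 2-methoxyphenyl in place of 4-methoxyphenyl on an amine nitrogen. Among the compounds with values here, no measured step moves a group around the ring; each one swaps one group for another at the same place, and each stayed within the scatter. That leaves the effect of this change open, but the measured steps give no reason to expect a large one. The number for compound 4 is expected to be about 2000 nM, within the range 800 nM to 5500 nM, which means an expected 1.2-fold higher number from compound 3 to compound 4 (0.08 log units; within the scatter).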

Compound 4, half-maximal inhibitory concentration: 1630 nM
For compound 4 the middle estimate is 1.2-fold (0.09 log units) above the measured one; the range from low to high includes it.
By their numbers in this assay, from the lowest: compounds 1, 2, 4 and 3 (each within the scatter of the next).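

Moving the methoxy group gives a 1.0-fold lower number from compound 3 to compound 4 (0.01 log units; within the scatter) in this assay and is the first measured step that changes where a group sits on this ring rather than which group is there. Position on the ring, for this methoxy group, therefore joins the identity of the group as a change that stays within the scatter, and the 2-methoxyphenyl group also reads alike with the 4-propylphenyl group, at a 1.0-fold higher number from compound 2 to compound 4 (0.02 log units; within the scatter) and with the 4-methylphenyl group, at a 1.1-fold higher number from compound 1 to compound 4 (0.06 log units; within the scatter) in the same assay. No measurement shown here offers an explanation for this flat picture.

On these data alone, what an amine or a carboxylic acid would do on this ring stays open. So does whether a plain phenyl ring with no added group would read the same in this assay.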